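Fluoro in place of nitro on the pendant benzylidene aryl

This account rests on a few compounds, and the source may have more. Where it says the series, first, only, none or still open, it means among the compounds named here.

Measured so far:
compound 1, `O=C1/C(=C/c2ccccc2)C=C(c2ccc(Cl)cc2)N1Cc1ccccc1`: 37%
compound 2, `O=C1/C(=C/c2ccc([N+](=O)[O-])cc2)C=C(c2ccc(Cl)cc2)N1Cc1ccccc1`: 19.8%

In a functional assay on the whole organism (strain Wistar) for inhibition, with Rattus norvegicus as the target, with stated times of 30 min and 3 h, at a dose of 20 mg/kg by the oral route (on this read-out lower numbers stand for less inhibition and higher numbers for more inhibition at the one dose given (going by the name of the read-out)), compound 1 gives 37% and compound 2 gives 19.8%. Going by the values given here, compound 2 stands at the lower of the two numbers; the only step measured, a number 17.2 percentage points lower from compound 1 to compound 2 (beyond the scatter), is beyond the scatter and is described as nitro in place of hydrogen on an aromatic carbon.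

Compound 3, `O=C1/C(=C/c2ccc(F)cc2)C=C(c2ccc(Cl)cc2)N1Cc1ccccc1`, has not been measured. It differs from compound 2 as follows: fluoro in place of nitro on an aromatic carbon. The step from compound 1 to compound 2 bears on this change only in part: it shows that putting nitro on this aromatic carbon lowered the inhibition, while nothing measured shows what fluoro does there. Removing the nitro is expected to recover some of that loss, with the fluoro itself treated as an unknown, so the estimated step is a number 10.2 percentage points higher from compound 2 to compound 3 (beyond the scatter), upward. Compound 3 is therefore expected to give about 30%, with a range from 16% to 44%.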

Compound 3, a percentage reported as inhibition, in the whole organism at one dose (the size of the read-out at that dose, not a potency): 89.5%
Compound 3: middle estimate off by 59.5 percentage points, on the low side; the measured number lies above the stated range.
By their numbers in this assay, from the lowest: compound 2; then compound 1; then compound 3.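

In this assay, this aromatic carbon proves far more sensitive than the earlier pair suggested, and substitution there need not lower the number: fluoro in place of hydrogen gives a number 52.5 percentage points higher from compound 1 to compound 3 (beyond the scatter). Fluoro in place of nitro gives a number 69.7 percentage points higher from compound 2 to compound 3 (beyond the scatter), so among these three compounds the group on this carbon moves the number in either direction from the unsubstituted compound 1, with nitro lowering it and fluoro raising it. Nothing available accounts for this difference between fluoro and nitro.

On these data alone, it remains open whether chloro, methoxy or an amine on this carbon would follow fluoro or nitro. Also open, as far as these compounds go, is whether fluoro would give a similar rise on another carbon of the same ring, or with a different group in place of the benzyl on the shared core.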